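From fluorophenyl to hydroxyphenyl on the shared core

This account rests on a few compounds, and the source may have more. Where it says the series, first, only, none or still open, it means among the compounds named here.

In a functional assay on the whole organism (strain Wistar) for inhibition, with Rattus norvegicus as the target, read by paw edema, with a stated time of 30 min, at a dose of 10 mg/kg by the intraperitoneal route (a higher number here means more inhibition at the dose given (going by the name of the read-out), a lower number less inhibition), two compounds have so far been measured:
compound 1, `O=C(N/N=C/c1cccc(F)c1)c1cccnc1Nc1cccc(C(F)(F)F)c1`, gives 58.3%
compound 2, `O=C(N/N=C/c1ccc(F)cc1)c1cccnc1Nc1cccc(C(F)(F)F)c1`, gives 33.9%

For the measured compounds named here, compound 2 stands lowest of the two numbers; its nearest neighbour is compound 1, and the single measured step, a number 24.4 percentage points lower from compound 1 to compound 2 (beyond the scatter), separates them. Compound 3, `O=C(N/N=C/c1cccc(O)c1)c1cccnc1Nc1cccc(C(F)(F)F)c1`, has not yet been measured in this assay. Its change from compound 2 is 3-hydroxyphenyl in place of 4-fluorophenyl on a carbon with a double bond to nitrogen.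

Going by the values given here, no measured step exchanges a fluorine for a hydroxyl, so the only step that bears on this one is the move of the fluorine from a 3-fluorophenyl to a 4-fluorophenyl, seen as a number 24.4 percentage points lower from compound 1 to compound 2 (beyond the scatter), a modest drop. Compound 3 carries a 3-hydroxyphenyl where compound 1 carries a 3-fluorophenyl, though the group itself is different. The step from compound 2 in this assay is expected to be a number 14.1 percentage points higher from compound 2 to compound 3 (beyond the scatter), upward yet uncertain. Compound 3 is therefore estimated at 48%, with a range from 30% to 66%.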

Compound 3, a percentage reported as inhibition, in the whole organism at one dose (the size of the read-out at that dose, not a potency): 67.5%
Estimate against measurement, compound 3: 19.5 percentage points below; measured number above the stated range.
By their numbers in this assay, from the lowest: compound 2; then compounds 1 and 3 (each within the scatter of the next).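

For the compounds shown here, the new compound gives the largest change at this position so far in this assay, with a step of a number 33.6 percentage points higher from compound 2 to compound 3 (beyond the scatter) on replacing 4-fluorophenyl with 3-hydroxyphenyl on the carbon with a double bond to nitrogen. The other step, hydroxy in place of fluoro on an aromatic carbon, reads a number 9.2 percentage points higher from compound 1 to compound 3 (within the scatter) and so separates the 3-hydroxyphenyl group from the 3-fluorophenyl group by no more than ordinary scatter, which leaves compound 2, with its 4-fluorophenyl, alone at the low end of these three compounds while compound 1 and compound 3 cannot be told apart. Nothing available here accounts for these differences.

The compounds shown leave open whether a 4-hydroxyphenyl group would read low like the 4-fluorophenyl group of compound 2 or high like the 3-hydroxyphenyl group of compound 3, since the step from compound 2 to compound 3 changes both the group and its name-given location on the ring. They also leave open how a methoxy group, an amine or a carboxylic acid would read in place of the hydroxy group of compound 3.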